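Naphthyl Substituent Swap: Expected Cytotoxicity of Compound 3

The source may hold more compounds than are shown below. What is called first, only, known or untested is meant among the compounds shown, and "the series" means these compounds.

Measured compounds:
compound 1 `Cc1cc(S(N)(=O)=O)ccc1NC(=O)COc1ccc(Cl)cc1Oc1ccc2ccccc2c1Cl`: 40700 nM
compound 2 `Cc1cc(S(N)(=O)=O)ccc1NC(=O)COc1ccc(F)cc1Oc1ccc2ccccc2c1Cl`: 47100 nM

In an ADME assay on C8166 cells (Homo sapiens) for cytotoxicity, read by MTT assay (on this read-out higher numbers stand for lower toxicity in this test and lower numbers for higher toxicity in this test), compound 1 gives 40700 nM and compound 2 gives 47100 nM. Compound 1 holds the lower of the two numbers, but the step of a 1.2-fold higher number from compound 1 to compound 2 (0.06 log units; within the scatter) shows that the two stand together within the scatter. Compound 3 `Cc1cc(S(N)(=O)=O)ccc1NC(=O)COc1ccc(Cl)cc1Oc1cc2ccccc2cc1C` differs from compound 1 by 3-methylnaphthalen-2-yl in place of 1-chloronaphthalen-2-yl on an oxygen on an aromatic ring. Within the data shown here, the only measured step, a 1.2-fold higher number from compound 1 to compound 2 (0.06 log units; within the scatter), touches a different part of the structure and is itself within the scatter, so no measured step bears on this change. The expectation is therefore no step beyond the scatter in this assay, with a wide range. Compound 3 is estimated at 40000 nM, between 18000 nM and 90000 nM, an expected step of a 1.0-fold lower number from compound 1 to compound 3 (0.01 log units; within the scatter).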

Compound 3, half-maximal cytotoxic concentration: 76700 nM
Estimate against measurement, compound 3: 1.9-fold (0.28 log units) below, and the stated range covers the measured number.
By their numbers in this assay, from the lowest: compounds 1, 2 and 3 (each within the scatter of the next).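

At this position, 3-methylnaphthalen-2-yl in place of 1-chloronaphthalen-2-yl gives a 1.9-fold higher number from compound 1 to compound 3 (0.28 log units; within the scatter) in this assay. This is the first step shown for the group on this oxygen, and it shows that this exchange stays within the scatter, as the step on the other ring did. No available evidence explains this result.

Among these compounds, the single swap removes the chlorine and adds the methyl together, so their separate contributions remain unresolved. From the compounds shown here alone, how an amine or a carboxylic acid in place of the methyl would read in this assay also remains open.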